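Swapping a fused heteroaryl for 3-cyanophenyl: expected solubility

The source may report more compounds than this note shows. Statements on the series, on what has been measured and on what is new or still open speak of the compounds shown alone.

Compound 1 `CNC(=O)c1cc(C(=O)NCCC2CCOCC2)cn(Cc2ccccc2)c1=O`: in a physicochemical assay for solubility (a lower number here means a less soluble compound, a higher number a more soluble compound), compound 1 gives >= 127 ug/mL, which is a limit of the assay and not a number.
Compound 2 `CNC(=O)c1cc(C(=O)NC(C)C)cn(Cc2ccccc2)c1=O`: compound 2 gives >= 136 ug/mL, again a limit rather than a number.
Compound 3 `CNC(=O)c1cc(C(=O)NC2CC2)cn(Cc2nccc3[nH]ccc23)c1=O`: compound 3 gives 73 ug/mL.

Going by the values given here, compound 3 therefore stands as the only real number among the three values; the other two are limits, namely the limit of >= 127 ug/mL in this assay, at which 1 of the 3 values shown sits, and (the limit of >= 136 ug/mL in this assay, at which 1 of the 3 values shown sits). Compound 4 `CNC(=O)c1cc(C(=O)NC2CC2)cn(Cc2cccc(C#N)c2)c1=O` differs from compound 3 by a group of 8 heavy atoms (7 carbon, 1 nitrogen; one six-membered aromatic ring of carbon only) in place of a group of 9 heavy atoms (7 carbon, 2 nitrogen; one five-membered aromatic ring with 1 hetero atom, one six-membered aromatic ring with 1 hetero atom), on a saturated chain carbon bound to an aromatic nitrogen. Among the compounds with values here, the single measured step, a step that the two limits leave unreadable from compound 1 to compound 2, sits between two limits and cannot be sized, and it alters a different part of the molecule, so no measured step bears on this change. The expectation for compound 4 rests on compound 3 alone and is held wide. Compound 4 is expected to give 50 ug/mL, within 18 ug/mL to 130 ug/mL, an expected step of a 1.5-fold lower number from compound 3 to compound 4 (0.16 log units; within the scatter).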

Compound 4, solubility: >= 148 ug/mL
Compound 4 was reported as a limit; the forecaster's own chance of this, stated with the estimate: 20%; at least 2.9-fold (0.47 log units) between middle value and limit.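

Putting 3-cyanophenyl on a saturated chain carbon bound to an aromatic nitrogen gives an at least 2.0-fold higher number from compound 3 to compound 4 (0.30 log units; that floor lies within the scatter) in this assay. This is the first step among these compounds that has any readable size, since the earlier step between two limits cannot be read, and it concerns a different part of the molecule. Compound 4 stands at a limit of the assay, not at a number: the limit of >= 148 ug/mL in this assay, at which 1 of the 4 values shown sits.

On these data alone, how far compound 4 lies past that limit remains open. Also open, as far as these compounds go, is how an amine or a carboxylic acid in place of the nitrile would read in this assay.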